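This account rests on a few compounds, and the source may have more. Where it says the series, first, only, none or still open, it means among the compounds named here.

Compound 2 `FC(F)(F)Oc1ccccc1-c1ccc2[nH]ncc2c1` was measured in an assay on CHO-TREX cells for antagonist activity at transient receptor potential cation channel subfamily A member 1 (Homo sapiens), read by FLIPR and calcium flux, with a stated time of 10 min (a higher number here means a weaker inhibitor, a lower number a stronger inhibitor), where compound 2 gives 3430 nM. The only other measured compound, compound 1 `Fc1ccccc1-c1ccc2[nH]ncc2c1`, gives 3950 nM in this assay, and the pair sit together: the change a 1.2-fold lower number from compound 1 to compound 2 (0.06 log units; within the scatter) is within the scatter, so no order can be read between the two numbers shown. Compound 3 `N#Cc1ccccc1-c1ccc2[nH]ncc2c1` differs from compound 2 by cyano in place of trifluoromethoxy on an aromatic carbon. Among the measured compounds shown here, the one measured step that bears on this change is the exchange of fluoro for trifluoromethoxy at the same aromatic carbon, and that step, a 1.2-fold lower number from compound 1 to compound 2 (0.06 log units; within the scatter), was small. For the measured compounds named here, since that is the only precedent and it showed no movement beyond the scatter, no step beyond the scatter is expected in this assay when cyano takes the place of trifluoromethoxy. Compound 3 is therefore expected to give 3200 nM, within a range from 1200 nM to 8500 nM. The expected step from compound 2 to compound 3 is a 1.1-fold lower number from compound 2 to compound 3 (0.03 log units; within the scatter).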

Compound 3, half-maximal inhibitory concentration: 1290 nM
Estimate against measurement, compound 3: 2.5-fold (0.39 log units) above; low and high end bracket the measured number.
By their numbers in this assay, from the lowest: compound 3; then compounds 2 and 1 (each within the scatter of the next).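

In this assay, this position proved able to move the number: a 2.7-fold lower number from compound 2 to compound 3 (0.42 log units; beyond the scatter), and a 3.1-fold lower number from compound 1 to compound 3 (0.49 log units; beyond the scatter), whereas the earlier exchange of fluoro for trifluoromethoxy had stayed within the scatter. Compound 3 is thus the only one of the three whose steps to both others lie beyond the scatter, so on this aromatic carbon, ortho to a group of 9 heavy atoms, the choice of group does matter, though the steps remain modest. Nothing at hand explains why cyano parts from the other two groups.

On these data alone, what an amine, a carboxylic acid or a longer chain would do on this carbon stays open. So does whether cyano would give a similar step elsewhere on the same ring, or on a different core.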